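The source may hold more compounds than are shown below. What is called first, only, known or untested is meant among the compounds shown, and "the series" means these compounds.

Within the data shown here, in a functional assay on HEK293 cells for agonist activity at D(4) dopamine receptor (Homo sapiens), read by FLIPR (a higher number here means that more compound is needed for the effect, a lower number that less compound is needed), compound 1 `CSc1cccc(NC(=O)CN2CCC(c3cccc[n+]3[O-])CC2)c1` gives 100 nM, the lowest of the two numbers known here. Compound 2 `Cc1cccc(C)c1NC(=O)CN1CCC(c2cccc[n+]2[O-])CC1` gives 346 nM, and the step of a 3.5-fold higher number from compound 1 to compound 2 (0.54 log units; beyond the scatter) came from exchanging the whole aryl group on the amide nitrogen. Compound 3 `O=C(CN1CCC(c2cccc[n+]2[O-])CC1)Nc1cccc(-c2ccccc2)c1` differs from compound 1 on that aryl ring: phenyl in place of methylsulfanyl on an aromatic carbon. Among the measured compounds shown here, no measured step covers this exchange itself; the only step known, a different exchange at that ring, was modest. Compound 3 is therefore expected to show a 1.6-fold higher number from compound 1 to compound 3 (0.20 log units; within the scatter), small and of uncertain direction. Compound 3 is thus estimated at 160 nM, with a range from 50 nM to 500 nM.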

Compound 3, half-maximal effective concentration: 360 nM
Estimate against measurement, compound 3: 2.3-fold (0.35 log units) below, and the stated range covers the measured number.
By their numbers in this assay, from the lowest: compound 1; then compounds 2 and 3 (each within the scatter of the next).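

In this assay, putting phenyl in place of methylsulfanyl on an aromatic carbon, meta to a large group, gives a 3.6-fold higher number from compound 1 to compound 3 (0.56 log units; beyond the scatter) and so shows that a change at this single position, with the rest of the aryl group kept, moves the number beyond the scatter. Compound 1 thus keeps the lowest number of the three. Nothing here gives a reason for this step.

On these data alone, it remains open whether a methoxy group, a chlorine atom or an amine at this position would match methylsulfanyl. As far as these compounds go, whether phenyl behaves the same way elsewhere on that ring also remains open.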